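Removing the Hydroxy Group from the Side Chain of Compound 3

The source may hold more compounds than are shown below. What is called first, only, known or untested is meant among the compounds shown, and "the series" means these compounds.

Of the compounds shown here, three sharing one core have been measured in a functional assay on L1210 cells (Mus musculus), with a stated time of 1 days; a higher number here means a more potent compound, by a factor of ten per unit of this negative logarithm, a lower number a less potent compound. Compound 1 `CCC(OC)C1=C(N2CC2)C(=O)C(C)=C(N2CC2)C1=O` gives 4.84, compound 2 `CC1=C(N2CC2)C(=O)C(COc2ccccc2)=C(N2CC2)C1=O` gives 3.89, and compound 3 `COC(CO)C1=C(N2CC2)C(=O)C(C)=C(N2CC2)C1=O` gives 5.27. Compound 3 thus stands highest of the three; its nearest neighbour is compound 1, and compound 2 lies furthest below it. For the measured compounds named here, the one measured step that changes a single place is a number 0.43 log units higher from compound 1 to compound 3 (beyond the scatter), a modest gain obtained by putting hydroxy in place of methyl on a saturated chain carbon, two bonds along the chain from a double-bonded ring carbon and an oxygen on a saturated carbon.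

Compound 4 `COCCC1=C(N2CC2)C(=O)C(C)=C(N2CC2)C1=O` is the next candidate. It differs from compound 3 in one place: 2-methoxyethyl in place of 2-hydroxy-1-methoxyethyl on a double-bonded ring carbon. In effect, the hydroxy group that set compound 3 apart from compound 1 is gone again. Going by the values given here, the step from compound 1 to compound 3 is the only guide, and it points the other way: taking away the group that brought the gain should cost roughly what it earned. The step from compound 3 to compound 4 in this assay is therefore expected to be a modest drop, a number 0.42 log units lower from compound 3 to compound 4 (beyond the scatter). Compound 4 is estimated at 4.85, with a likely range from 4.4 to 5.3.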

Compound 4, logarithm of the reciprocal of the active concentration, log(1/C): 5.12
Beside the measured number, compound 4's estimate is 0.27 log units below it; low and high end bracket the measured number.
By their numbers in this assay, from the lowest: compound 2; then compounds 1, 4 and 3 (each within the scatter of the next, the first and the last beyond it).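

In this assay, the step of a number 0.15 log units lower from compound 3 to compound 4 (within the scatter) shows that this double-bonded ring carbon can carry a side chain with 0 hydrogen-bond donors in place of one with 1 donor, with no change that can be told from scatter, so the hydroxy group is not needed for this pair to keep its number. The step of a number 0.28 log units higher from compound 1 to compound 4 (within the scatter) adds that 2-methoxyethyl cannot be told apart from 1-methoxypropyl either, which places compound 4 within the scatter of two compounds that are themselves separated beyond it. The far larger difference lies elsewhere: the step of a number 1.23 log units higher from compound 2 to compound 4 (beyond the scatter), with methoxymethyl in place of phenoxy on a saturated chain carbon bound to a double-bonded ring carbon, shows that among these compounds only the one carrying phenoxy falls well away from the rest. Nothing available here explains any of these numbers. Still open, as far as these compounds go, is whether an amine or a carboxylic acid in this side chain would keep the number in this assay. From the compounds shown here alone, a longer chain such as 4-methoxybutyl on the same ring carbon is equally open.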